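Aryl exchange at the hydrazone carbon: thiophene in place of chlorophenyl

The compounds below may be only part of what the source reports. "The series", "measured", "known", "first", "only" and "open" are said of these compounds alone.

Among the compounds with values here, in a functional assay on NCI-H460 cells (Homo sapiens) for inhibition, read by sulforhodamine B assay, with a stated time of 48 h (a lower number here means a stronger inhibitor of growth, a higher number a weaker inhibitor of growth), compound 2 (`CC1=CC[C@H](C(C)(C)NC(=S)N/N=C/c2ccccc2Cl)CC1`) gives 81000 nM, the only plain number in the set. Compound 1 (`CC1=CC[C@H](C(C)(C)NC(=S)N/N=C/c2ccc(F)cc2)CC1`) reaches only a limit of this assay, > 100000 nM, as noted at the limit of > 100000 nM in this assay, at which 1 of the 2 values shown sits. Within the data shown here, the single measured step, an at least 1.2-fold lower number from compound 1 to compound 2 (0.09 log units; that floor lies within the scatter), concerns a different exchange and stays within the scatter. Compound 3 (`CC1=CC[C@H](C(C)(C)NC(=S)N/N=C/c2cccs2)CC1`) differs by thiophen-2-yl in place of 2-chlorophenyl on a carbon with a double bond to nitrogen. Among the measured compounds shown here, no measured step bears directly on this change, so no shift beyond the scatter is expected; the step is estimated as a 1.1-fold higher number from compound 2 to compound 3 (0.05 log units; within the scatter). Compound 3 is therefore expected near 90000 nM, within 40000 nM to 200000 nM.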

Compound 3, concentration for total growth inhibition: 20800 nM
For compound 3 the middle estimate is 4.3-fold (0.64 log units) above the measured one; the whole stated range lies above it.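

Within the data shown here, the group on a carbon with a double bond to nitrogen does affect growth inhibition in this assay: the change to thiophen-2-yl gives a 3.9-fold lower number from compound 2 to compound 3 (0.59 log units; beyond the scatter), the first step beyond the scatter, and an at least 4.8-fold lower number from compound 1 to compound 3 (0.68 log units; beyond the scatter). Compound 1 stands at a limit of the assay, so that second step is only a floor: the limit of > 100000 nM in this assay, at which 1 of the 3 values shown sits. Still open, from the compounds shown here alone, is whether the shift is specific to thiophen-2-yl or extends to other five-membered aromatic rings such as furan-2-yl. Going by these compounds, how a pyridin-2-yl ring or a phenyl ring bearing an amine would behave at this carbon is also open.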